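Urea to thiourea on the hydroxybenzyl ether series

A few compounds are considered here, and "the series" means these few. Any claim that something is new, unique, unknown or untested is made for them only; others in the source may bear on it.

Measured compounds:
- compound 1 `O=S(=O)(NCCNC(=S)Nc1cccc(Cl)c1)c1ccc(-c2ccccc2OCc2ccccc2)s1`: > 50000 nM
- compound 2 `O=[N+]([O-])c1ccc(Oc2ccccc2-c2ccc(S(=O)(=O)NCCNC(=S)Nc3cccc(Cl)c3)s2)cc1`: > 50000 nM
- compound 3 `O=C(NCCNS(=O)(=O)c1ccc(-c2ccccc2OCc2cccc(O)c2)s1)Nc1cc(Cl)cc(Cl)c1`: 2800 nM

In a functional assay on HL-60 cells (Homo sapiens) for inhibition, read by CCK-8 assay, with a stated time of 48 h (a higher number here means a weaker inhibitor, a lower number a stronger inhibitor), compound 1 gives only a limit, > 50000 nM. Compound 2 likewise gives only a limit in this assay, > 50000 nM. Going by the values given here, the single step among the measured compounds, a step that the two limits leave unreadable from compound 1 to compound 2, is therefore unreadable. Among the compounds with values here, compound 3 gives the only number in the set, 2800 nM, and stands apart from the limit of > 50000 nM in this assay, at which 2 of the 3 values shown sit.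

Compound 4 `O=S(=O)(NCCNC(=S)Nc1cccc(Cl)c1)c1ccc(-c2ccccc2OCc2cccc(O)c2)s1` is yet to be measured. It differs from compound 3 in one place: a group of 10 heavy atoms (7 carbon, 1 nitrogen, 1 sulfur, 1 chlorine; one six-membered aromatic ring of carbon only) in place of a group of 11 heavy atoms (7 carbon, 1 nitrogen, 1 oxygen, 2 chlorine; one six-membered aromatic ring of carbon only), on an amine nitrogen. Within the data shown here, no measured pair shows this change, so its size cannot be read from the steps. Compound 4 shares its carbamothioyl-bearing end with compound 1 and compound 2 and shares its ether end with compound 3.

The expectation for compound 4 is a loss against compound 3, a 5.4-fold higher number from compound 3 to compound 4 (0.73 log units; beyond the scatter), with a real chance of a limit only. Compound 4 is expected at 15000 nM in this assay, within 3000 nM to 60000 nM.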

Compound 4, half-maximal inhibitory concentration: 1800 nM
For compound 4 the middle estimate is 8.3-fold (0.92 log units) above the measured one; measured number outside the range, below it.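

In this assay, hydroxy in place of hydrogen on an aromatic carbon gives an at least 27-fold lower number from compound 1 to compound 4 (1.44 log units; beyond the scatter), the first readable effect at this position, where compound 1 and compound 2 gave only a limit: the limit of > 50000 nM in this assay, at which 2 of the 4 values shown sit.

3-Hydroxybenzyl in place of 4-nitrophenyl on the oxygen gives an at least 27-fold lower number from compound 2 to compound 4 (1.44 log units; beyond the scatter), but this exchanges the whole ether group and so does not isolate the hydroxy. On the amine nitrogen, the exchange of the (3,5-dichlorophenyl)carbamoyl group gives a 1.6-fold lower number from compound 3 to compound 4 (0.19 log units; within the scatter), so with the 3-hydroxybenzyl ether in place, the urea and thiourea ends are not told apart in this assay.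

As far as these compounds go, whether a methoxy group or an amine can stand in for the hydroxy remains open. So does the effect of a longer chain on the amine nitrogen.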